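The source may hold more compounds than are shown below. What is called first, only, known or untested is meant among the compounds shown, and "the series" means these compounds.

Compound 1, `Cc1ccc(S(=O)(=O)N2CCC(N3CCC(C)CC3)CC2)cc1C`, in a functional assay on DLD-1 cells (Homo sapiens) for antiproliferative activity, read by CellTiter-Glo, with a stated time of 72 h; a lower number here means a stronger inhibitor, a higher number a weaker inhibitor: 24 nM
Compound 2, `CC1CCN(C2CCN(S(=O)(=O)c3cccc(-c4ccc5ccccc5c4)c3)CC2)CC1`, in this assay: 2 nM

Of the compounds shown here, two have been measured so far. Compound 1 gives the higher of the two numbers, so it is the weaker inhibitor of the pair; compound 2 gives a number far enough below it to lie beyond the usual scatter. Among the measured compounds shown here, no single-change step connects these two, so only their two values can be set side by side.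

The next compound, compound 3, `CC1CCN(C2CCN(S(=O)(=O)c3ccc(Cl)cc3Cl)CC2)CC1`, is a new variant of compound 1 that has not yet been measured in this assay. The two differ in one place: 2,4-dichlorophenyl in place of 3,4-dimethylphenyl on a sulfonyl sulfur. For the measured compounds named here, no measured pair shows the effect of this kind of swap, so there is no basis for expecting a large shift in either direction, and the step is expected to stay within the scatter. Compound 3 is therefore estimated at 30 nM, with a range from 8 nM to 120 nM, which means a step of a 1.3-fold higher number from compound 1 to compound 3 (0.10 log units; within the scatter) is expected.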

Compound 3, half-maximal inhibitory concentration: 1 nM
Estimate against measurement, compound 3: 30-fold (1.48 log units) above; the whole stated range lies above it.
By their numbers in this assay, from the lowest: compounds 3 and 2 (each within the scatter of the next); then compound 1.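

In this assay, placing 2,4-dichlorophenyl on the sulfonyl sulfur in place of 3,4-dimethylphenyl gives a 24-fold lower number from compound 1 to compound 3 (1.38 log units; beyond the scatter), so this place in the molecule strongly affects the result. The two groups have the same heavy-atom count, the same single six-membered aromatic ring, no hydrogen-bond donors or acceptors and no net charge, so these counts alone do not account for the size of the step. No measurement shown here explains why the swap has so large an effect.

The swap changes both the kind of substituent and the numbered positions it occupies, so its two parts cannot be separated: 2,4-dimethylphenyl and 3,4-dichlorophenyl would each carry only one of them. As far as these compounds go, how a phenyl bearing an amine or a carboxylic acid would behave at this sulfonyl sulfur also remains open.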